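Dropping the Fluorine from the Aryl Urea of Compound 3

This account rests on a few compounds, and the source may have more. Where it says the series, first, only, none or still open, it means among the compounds named here.

Compound 1 `O=C(Nc1cccc(C(F)(F)F)c1)N[C@H]1CC[C@H](Oc2cccc(F)c2)CC1` gives 2400 nM in a functional assay on CRL2813 cells (Homo sapiens) for cytotoxicity, read by sulforhodamine B assay, with a stated time of 5 days; a higher number here means a weaker inhibitor, a lower number a stronger inhibitor.
Compound 2 `O=C(Nc1cccc(C(F)(F)F)c1)N[C@H]1CC[C@@H](Oc2ccc(F)cc2)CC1` gives 2600 nM in this assay.
Compound 3 `O=C(Nc1ccccc1F)N[C@H]1CC[C@H](Oc2ccc(F)cc2)CC1` gives 17500 nM in this assay.

Compound 3 carries the highest number of the three and is therefore the weakest inhibitor of the set; its gaps to compound 2 and to compound 1 both lie beyond the usual scatter. Compound 4 `O=C(Nc1ccccc1)N[C@H]1CC[C@H](Oc2ccc(F)cc2)CC1` differs from compound 3 in a single spot: hydrogen in place of fluoro on an aromatic carbon. Among the compounds with values here, no measured pair isolates this particular change, so there is no direct precedent to lean on. The expectation is a step from compound 3 to compound 4 in this assay of a 1.1-fold higher number from compound 3 to compound 4 (0.06 log units; within the scatter), at most a modest shift and quite possibly none beyond the scatter. Compound 4 is thus estimated at 20000 nM, within a range from 7000 nM to 60000 nM.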

Compound 4, half-maximal inhibitory concentration: 20000 nM
For compound 4 middle estimate and measured number coincide at the digits printed; the range from low to high includes it.
By their numbers in this assay, from the lowest: compounds 1 and 2 (each within the scatter of the next); then compounds 3 and 4 (each within the scatter of the next).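

Going from 2-fluorophenyl to phenyl gives a 1.1-fold higher number from compound 3 to compound 4 (0.06 log units; within the scatter) in this assay. Within the data shown here, this is the first pair to isolate hydrogen in place of fluoro on this aromatic carbon, and it shows that, between these two compounds, the fluoro ortho to a large group makes no difference beyond the scatter. No supporting data are available to explain this outcome.

Still open, as far as these compounds go, is whether a larger group on the same aromatic carbon, such as a methoxy group or an amine, would shift the number.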